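The compounds below may be only part of what the source reports. "The series", "measured", "known", "first", "only" and "open" are said of these compounds alone.

Compound 3 `CC(C)(C)n1cc2c(n1)C(=O)CC1(CCN(C(=O)c3cc(-c4ccc(Br)cc4)nc4ccccc34)CC1)O2` gives 820 nM in a functional assay on HepG2 cells (Homo sapiens) for inhibition, read by MTT assay, with a stated time of 72 h; on this read-out higher numbers stand for weaker inhibition and lower numbers for stronger inhibition. Compound 1 `CC(C)(C)n1cc2c(n1)C(=O)CC1(CCN(C(=O)c3cc(-c4ccc(Cl)cc4)nc4ccccc34)CC1)O2` gives 630 nM, which leaves compound 3 with the higher of the two numbers, although a 1.3-fold higher number from compound 1 to compound 3 (0.11 log units; within the scatter) and so sits within the scatter. Compound 2 `CC(C)(C)n1cc2c(n1)C(=O)CC1(CCN(C(=O)c3cc(-c4ccccc4Cl)nc4ccccc34)CC1)O2` returns only a limit, > 10000 nM. Moving the halogen to another place on the ring cost heavily: an at least 15-fold higher number from compound 1 to compound 2 (1.20 log units; beyond the scatter). Compound 4 `CC(C)(C)n1cc2c(n1)C(=O)CC1(CCN(C(=O)c3cc(-c4ccc(N)cc4)nc4ccccc34)CC1)O2` carries amino in place of bromo on an aromatic carbon. For the measured compounds named here, the only measured step at this place is a 1.3-fold higher number from compound 1 to compound 3 (0.11 log units; within the scatter), a swap between two halogens; no measured step exchanges a halogen for an amino group, so the direction is open. A modest weakening is expected, a 1.8-fold higher number from compound 3 to compound 4 (0.26 log units; within the scatter). Compound 4 is estimated at 1500 nM, with a range of 400 nM to 6000 nM.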

Compound 4, half-maximal inhibitory concentration: 630 nM
Beside the measured number, compound 4's estimate is 2.4-fold (0.38 log units) above it; low and high end bracket the measured number.
By their numbers in this assay, from the lowest: compounds 1, 4 and 3 (each within the scatter of the next). At a limit, above all of these: compound 2.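

In this assay this place takes an amino group as well as a halogen: a 1.3-fold lower number from compound 3 to compound 4 (0.11 log units; within the scatter), and no change at the digits printed from compound 1 to compound 4 (within the scatter). For the compounds shown here, the earlier pair held only halogens, so 4-aminophenyl is the first non-halogen here to stay level with them, and 2-chlorophenyl remains the change that stands apart: an at least 15-fold lower number from compound 2 to compound 4 (1.20 log units; beyond the scatter). Compound 2 is a limit and not a number: the limit of > 10000 nM in this assay, at which 1 of the 4 values shown sits.

Going by these compounds, whether a carboxylic acid, a methoxy group or a longer chain at this place stays level remains open. So does whether an amino group moved elsewhere on the ring would follow the chloro of compound 2.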